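Capping the hydroxy group of compound 3 with ethoxycarbonyl

A few compounds are considered here, and "the series" means these few. Any claim that something is new, unique, unknown or untested is made for them only; others in the source may bear on it.

In a functional assay on SW707 cells (Homo sapiens) for antiproliferative activity, with a stated time of 72 h (on this read-out lower numbers stand for stronger inhibition and higher numbers for weaker inhibition), compound 3 `CSc1cnc2ccccc2c1SCC#CCO` gives 34.9 ug/mL; compound 1 `OCC#CCSc1cnc2ccccc2c1SCC#CCCl` gives 19.8 ug/mL, which lies within the scatter of compound 3, while compound 2 `OCC#CCSc1cnc2ccccc2c1Cl` gives 6.2 ug/mL, a lower number than compound 3 and beyond the scatter. Compound 4 `CCOC(=O)OCC#CCSc1c(SC)cnc2ccccc12` differs from compound 3 by ethoxycarbonyl in place of hydrogen on an oxygen on a saturated carbon. Going by the values given here, the only measured step, a 3.2-fold lower number from compound 1 to compound 2 (0.50 log units; beyond the scatter), alters a different part of the shared core and leaves the hydroxy group untouched, so no measured step bears directly on this change. For compound 4 the account therefore expects only a small step, a 1.4-fold lower number from compound 3 to compound 4 (0.14 log units; within the scatter), toward a somewhat lower number, close to the scatter. Compound 4 is estimated at 25 ug/mL, with a range from 9 ug/mL to 70 ug/mL.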

Compound 4, concentration for 50% inhibition: 33.1 ug/mL
Compound 4: middle estimate off by 1.3-fold (0.12 log units), on the low side, within the range that was stated.
By their numbers in this assay, from the lowest: compound 2; then compounds 1, 4 and 3 (each within the scatter of the next).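

In this assay the change at this oxygen on a saturated carbon gives (a 1.1-fold lower number from compound 3 to compound 4 (0.02 log units; within the scatter)), so ethoxycarbonyl can take the place of the hydrogen with no shift beyond the scatter. Going by these compounds alone, this is the first measured step at the hydroxy group, as the earlier step altered a different part of the shared core. No evidence at hand explains this result. As far as these compounds go, whether an amine or a carboxylic acid in place of the hydroxy group would leave the number equally unmoved stays open. So does whether ethoxycarbonyl on the hydroxy group of compound 2 would behave alike.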